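Aryl changes on a shared core, fluorophenyl to bromofuran

A few compounds are considered here, and "the series" means these few. Any claim that something is new, unique, unknown or untested is made for them only; others in the source may bear on it.

Values from a functional assay on the whole organism with Mus musculus as the target; on this read-out lower numbers stand for an effect already at smaller amounts and higher numbers for an effect only at larger amounts of compound
compound 1 `CN(C)C(=O)Cn1c(-c2ccc(Br)cc2)nc2cccnc21` gives 7 mg/kg
compound 2 `CN(C)C(=O)Cn1c(-c2ccc(F)cc2)nc2cccnc21` gives 40.5 mg/kg
compound 3 `CN(C)C(=O)Cn1c(-c2ccc([N+](=O)[O-])cc2)nc2cccnc21` gives 47 mg/kg

Compound 2 sits in the upper pair of the three numbers. That pair cannot be told apart (a 1.2-fold higher number from compound 2 to compound 3 (0.06 log units; within the scatter)), while the lowest number stands clear of both (a 5.8-fold higher number from compound 1 to compound 2 (0.76 log units; beyond the scatter) and a 6.7-fold higher number from compound 1 to compound 3 (0.83 log units; beyond the scatter)). Compound 4 `CN(C)C(=O)Cn1c(-c2ccc(Br)o2)nc2cccnc21` carries 5-bromofuran-2-yl in place of 4-fluorophenyl on an aromatic carbon on the shared core. Among the measured compounds shown here, no furan has been measured, so the only guide is compound 1 with its bromo at 7 mg/kg on a phenyl ring, and that guide carries over only in part. The expected step (a 2.5-fold lower number from compound 2 to compound 4 (0.40 log units; beyond the scatter)) is modest, toward a lower number in this assay and smaller than the gap seen for the bromo. Compound 4 is estimated at 16 mg/kg (expected range 6 mg/kg to 42 mg/kg).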

Compound 4, dose for half-maximal effect: 100 mg/kg
For compound 4 the middle estimate is 6.3-fold (0.80 log units) below the measured one; measured number outside the range, above it.
By their numbers in this assay, from the lowest: compound 1; then compounds 2 and 3 (each within the scatter of the next); then compound 4.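

In this assay, exchanging 4-bromophenyl for 5-bromofuran-2-yl gives the largest step yet at this position (a 14-fold higher number from compound 1 to compound 4 (1.15 log units; beyond the scatter)), and the exchange from 4-fluorophenyl points the same way (a 2.5-fold higher number from compound 2 to compound 4 (0.39 log units; beyond the scatter)). The low number of compound 1 therefore does not follow the bromo onto a five-membered aromatic ring, so the ring itself counts here, not only its substituent. Nothing at hand explains this. From the compounds shown here alone, it remains open whether an unsubstituted furan or a bromothiophene would separate the effect of the ring from that of the bromine, and whether a 4-chlorophenyl group would come close to compound 1.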